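Trimming the amine side chain of compound 2

A few compounds are considered here, and "the series" means these few. Any claim that something is new, unique, unknown or untested is made for them only; others in the source may bear on it.

In a functional assay on HepG2 cells (Homo sapiens) for antiproliferative activity, read by CCK-8 assay, with a stated time of 48 h (a higher number here means a weaker inhibitor, a lower number a stronger inhibitor), compound 1 `COc1ccc(/C=C\c2cc(OC)c(OC)c(OC)c2)cc1OCc1ccc(CN[C@H](C(=O)O)[C@H](C)O)cc1` returns > 10000 nM as a limit of the assay and not a number. Going by the values given here, compound 2 `COc1ccc(/C=C\c2cc(OC)c(OC)c(OC)c2)cc1OCc1ccc(CNCCO)cc1` gives 5900 nM as the only true number so far, so its standing rests on that single reading. Compound 3 `COc1ccc(/C=C\c2cc(OC)c(OC)c(OC)c2)cc1OCc1ccc(CO)cc1` has not yet been measured. It departs from compound 2 by hydroxy in place of (2-hydroxyethyl)amino on a saturated chain carbon bound to an aromatic carbon in one place, a saturated chain carbon bound to an aromatic carbon. Among the compounds with values here, one measured step bears on this, namely an at least 1.6-fold lower number from compound 1 to compound 2 (0.22 log units; that floor lies within the scatter) with 2-hydroxyethyl in place of 1-carboxy-2-hydroxypropyl on an amine nitrogen. Within the data shown here, its floor lies within the scatter, and no measured compound lacks the amine, so it offers only a weak guide. A modest move toward a lower number is therefore expected, an estimated 2.0-fold lower number from compound 2 to compound 3 (0.29 log units; within the scatter) in this assay that may not clear the scatter. For compound 3 the estimated value is 3000 nM with an expected range of 700 nM to 10000 nM on the evidence at hand.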

Compound 3, half-maximal inhibitory concentration: 2400 nM
Estimate against measurement, compound 3: 1.3-fold (0.10 log units) above, within the range that was stated.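

In this assay, going by these compounds alone, hydroxy in place of (2-hydroxyethyl)amino on a saturated chain carbon bound to an aromatic carbon gives a 2.5-fold lower number from compound 2 to compound 3 (0.39 log units; beyond the scatter), the first single change here that stands clear of the scatter, and it shows that the amine nitrogen carried by the earlier compounds is not required for a value at this level. The larger change, hydroxy in place of (1-carboxy-2-hydroxypropyl)amino at the same place, gives an at least 4.1-fold lower number from compound 1 to compound 3 (0.61 log units; beyond the scatter). The value of compound 1 is a limit of the assay and not a number, so that step is only a floor: the limit of > 10000 nM in this assay, at which 1 of the 3 values shown sits.

The compounds shown leave open whether the lower number follows the loss of the amine nitrogen or the smaller size of the group that enters, and a primary amine or a carboxylic acid at this place would help separate the two. From the compounds shown here alone, it is also open whether the hydroxy itself adds anything, which a methoxy or a fluorine in its place would test.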